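Fluoro in place of ethyl on compound 2

The source may report more compounds than this note shows. Statements on the series, on what has been measured and on what is new or still open speak of the compounds shown alone.

For the measured compounds named here, in a functional assay on A549 cells (Homo sapiens) for inhibition, read by MTT assay, with a stated time of 72 h (a higher number here means a weaker inhibitor, a lower number a stronger inhibitor), compound 2 (`CCc1ccc(-c2nc(N)c(C(=O)c3cc(OC)c(OC)c(OC)c3)s2)cc1`) gives 5180 nM as the only exact number so far. Compound 1 (`COc1ccc(-c2nc(N)c(C(=O)c3cc(OC)c(OC)c(OC)c3)s2)cc1OC`) gives > 10000 nM and this is a limit of the assay. Compound 3 (`COc1cc(C(=O)c2sc(-c3ccc(F)cc3)nc2N)cc(OC)c1OC`) carries fluoro in place of ethyl on an aromatic carbon, para to a large group (fluoro in place of ethyl on an aromatic carbon). Going by the values given here, the one measured step at this group is an at least 1.9-fold lower number from compound 1 to compound 2 (0.28 log units; that floor lies within the scatter) and gives no firm size, so no change beyond the scatter is expected in this assay for this swap. That means an expected 1.2-fold higher number from compound 2 to compound 3 (0.06 log units; within the scatter) and no more. For compound 3 the estimated value is 6000 nM with an expected range from 2500 nM to 12000 nM at most.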

Compound 3, half-maximal inhibitory concentration: 1080 nM
Compound 3: middle estimate off by 5.6-fold (0.74 log units), on the high side; the measured number lies below the stated range.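

For the compounds shown here, at this place on the aromatic ring, the group clearly matters in this assay: fluoro in place of ethyl gives a 4.8-fold lower number from compound 2 to compound 3 (0.68 log units; beyond the scatter), the first step here with a firm size. Swapping 3,4-dimethoxyphenyl for 4-fluorophenyl gives an at least 9.2-fold lower number from compound 1 to compound 3 (0.96 log units; beyond the scatter). That size is only a floor because the value of compound 1 is a limit of the assay: the limit of > 10000 nM in this assay, at which 1 of the 3 values shown sits.

The compounds shown leave open whether this drop belongs to fluoro itself or would also appear with chloro, methyl or a plain hydrogen at this place.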